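This account rests on a few compounds, and the source may have more. Where it says the series, first, only, none or still open, it means among the compounds named here.

Measured so far:
- compound 1 `CN(C)c1ccc(/C=C2\C(=O)N(c3c(Cl)cccc3Cl)c3ccccc32)cc1`: > 100 ug/mL in a functional assay on L132 cells (Homo sapiens) for cytotoxicity, read by MTT assay, with a stated time of 72 h; on this read-out lower numbers stand for an effect already at smaller amounts and higher numbers for an effect only at larger amounts of compound
- compound 2 `O=C1/C(=C\c2cccc(Br)c2)c2ccccc2N1c1c(Cl)cccc1Cl`: 19 ug/mL in this assay

For compound 1 the value is a limit of the assay rather than a number. Among the compounds with values here, compound 2 therefore stands as the only number in this set, with the one other value being a limit. Compound 3 `O=C1/C(=C\c2ccc(Cl)cc2)c2ccccc2N1c1c(Cl)cccc1Cl` has not yet been measured in this assay. It differs from compound 2 in one place: 4-chlorophenyl in place of 3-bromophenyl on a double-bonded chain carbon bound to a double-bonded ring carbon.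

Within the data shown here, the one measured step that touches the same place is an at least 5.2-fold lower number from compound 1 to compound 2 (0.72 log units; beyond the scatter), an exchange of one aromatic group for another on that chain carbon. Its exact size is not known, since the limit of > 100 ug/mL in this assay, at which 1 of the 2 values shown sits, applies to one side of it. Among the measured compounds shown here, the change from compound 2 to compound 3 is a smaller one, exchanging one halogen-bearing phenyl for another, and no measured pair compares two such groups directly, so the expectation rests on compound 2 alone. A step within the usual scatter is expected, a 1.1-fold higher number from compound 2 to compound 3 (0.02 log units; within the scatter). Compound 3 is therefore estimated at 20 ug/mL, between 8 ug/mL and 50 ug/mL.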

Compound 3, concentration for half-maximal effect: 9 ug/mL
Compound 3: the middle estimate sits 2.2-fold (0.35 log units) above what was measured; the range from low to high includes it.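

In this assay, two halogen-bearing phenyl groups on the double-bonded chain carbon can now be compared directly, and the exchange gives a 2.1-fold lower number from compound 2 to compound 3 (0.32 log units; beyond the scatter). So even a swap of 3-bromophenyl for 4-chlorophenyl, two groups with the same heavy-atom count and no hydrogen-bond donors or acceptors, moves the value beyond the scatter at this position. The 4-chlorophenyl group also allows a comparison in which only the group on the aromatic carbon changes, chloro in place of dimethylamino, and this gives an at least 11-fold lower number from compound 1 to compound 3 (1.04 log units; beyond the scatter), although compound 1 gives only a limit, not a number, so the true size of that step stays unknown: the limit of > 100 ug/mL in this assay, at which 1 of the 3 values shown sits.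

The exchange from 3-bromophenyl to 4-chlorophenyl alters both the halogen and its place on the ring, and with neither 4-bromophenyl nor 3-chlorophenyl among the compounds shown, these two changes cannot be told apart. Also open, on these data alone, is how a plain phenyl group or a 4-methoxyphenyl group on the same chain carbon would read in this assay.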